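The compounds below may be only part of what the source reports. "The series", "measured", "known", "first", "only" and "open" are said of these compounds alone.

Measured so far:
compound 1 `COCNC(=O)c1cc(Br)c(Br)[nH]1`, 21.5 ug/mL
compound 2 `COC(=O)CC1CNC(=O)c2cc(Br)c(Br)n21`, 30 ug/mL

Both were tested in a functional assay on P388 cells (Mus musculus) for cytotoxicity; on this read-out lower numbers stand for an effect already at smaller amounts and higher numbers for an effect only at larger amounts of compound. Compound 2 gives 30 ug/mL there, and compound 1 gives 21.5 ug/mL; the two numbers lie within the scatter of each other, so no difference between them is established. Compound 3 `O=C1NCC(O)n2c1cc(Br)c2Br` has not yet been measured. It differs from compound 2 in one respect: hydroxy in place of (methoxycarbonyl)methyl on a saturated ring carbon. Among the measured compounds shown here, no step between measured compounds exists to guide this change, so no shift beyond the scatter is expected in this assay. Compound 3 is therefore expected to give about 30 ug/mL, between 10 ug/mL and 100 ug/mL, which means an estimated step of no change at the digits printed from compound 2 to compound 3 (within the scatter).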

Compound 3, concentration for half-maximal effect: > 100 ug/mL
Compound 3 gave a limit, no number (the forecaster's own chance of this, stated with the estimate: 20%); middle value at least 3.3-fold (0.52 log units) away from the limit.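

In this assay, putting hydroxy in place of (methoxycarbonyl)methyl on this saturated ring carbon moves the read-out beyond the scatter, with an at least 3.3-fold higher number from compound 2 to compound 3 (0.52 log units; beyond the scatter). What sits on this carbon therefore matters for the effect on these cells, which compounds 1 and 2 alone could not show. The result for compound 3 is a limit, not a number: the limit of > 100 ug/mL in this assay, at which 1 of the 3 values shown sits.

Still open, on these data alone, is whether the hydroxy itself or the missing ester chain accounts for this step. A carboxylic acid, an amine or a plain methyl on this carbon would help to tell these apart.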